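This account rests on a few compounds, and the source may have more. Where it says the series, first, only, none or still open, it means among the compounds named here.

In an ADME assay on HepG2 cells (Homo sapiens) for cytotoxicity, read by MTT assay, with a stated time of 72 h (on this read-out lower numbers stand for higher toxicity in this test and higher numbers for lower toxicity in this test), compound 1 (`O=[N+]([O-])c1cnc2c(Br)cc(Cl)cn12`) gives 16200 nM as a measured number. Compound 3 (`CSCc1nc2c(Br)cc(Cl)cn2c1[N+](=O)[O-]`) shows > 15600 nM as a limit only. Compound 2 (`O=[N+]([O-])c1c(CS(=O)(=O)c2ccccc2)nc2c(Nc3ccc(Cl)cc3)cc(Cl)cn12`) shows > 3900 nM as a limit too, so its exact place among the numbers shown stays open. Compound 4 (`O=[N+]([O-])c1c(CS(=O)(=O)c2ccccc2)nc2c([Se]c3ccc(Cl)cc3)cc(Cl)cn12`) carries a group of 8 heavy atoms (6 carbon, 1 chlorine, 1 selenium; one six-membered aromatic ring of carbon only) in place of a group of 8 heavy atoms (6 carbon, 1 nitrogen, 1 chlorine; one six-membered aromatic ring of carbon only), on an aromatic carbon on an aromatic carbon and otherwise matches compound 2. Within the data shown here, the only measured step is a step that the limit leaves unreadable from compound 1 to compound 3 and it concerns a different change, so it offers no size to carry over. No direction can be read from the data, and the expected step in this assay is a step that the limit leaves unreadable from compound 2 to compound 4 and no more than the usual scatter. Compound 4 is estimated at 6000 nM with 2000 nM to 18000 nM as the expected range.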

Compound 4, half-maximal cytotoxic concentration: > 7800 nM
Compound 4: only a limit was reported (the forecaster's own chance of this, stated with the estimate: 60%); middle value at least 1.3-fold (0.11 log units) from the limit.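

Among these compounds, compound 2 and compound 4 are each known only as a limit in this assay, so no step between them can be read. The compounds shown leave open whether replacing the (4-chlorophenyl)amino group with the selenium-bearing group changes toxicity in this test at all, and in which direction.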